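This account rests on a few compounds, and the source may have more. Where it says the series, first, only, none or still open, it means among the compounds named here.

In a functional assay on HeLa cells (Homo sapiens) for inhibition, read by MTT assay, with a stated time of 72 h (on this read-out higher numbers stand for weaker inhibition and lower numbers for stronger inhibition), compound 1, `COc1cc(OC)c(OC)cc1/C=C/C(=O)c1ccc(Cl)cc1`, gives 36500 nM. Compound 2, `COc1cc(OC)c(OC)cc1/C=C/C(=O)c1cc(OC(C)=O)ccc1OC(C)=O`, gives 57900 nM in this assay, a number within the scatter of that of compound 1, so the two cannot be told apart. Compound 3, `COc1cc(OC)c(C(=O)/C=C/c2cc(OC)c(OC)cc2OC)c(OC)c1`, gives 108000 nM, a higher number than compound 1 by a gap beyond the scatter, so compound 1 holds the lowest number of the three and inhibits more strongly than compound 3. Compound 4, `COc1cc(OC)c(OC)cc1/C=C/C(=O)c1ccc(Br)cc1`, has not yet been measured. It differs from compound 1 in one place: bromo in place of chloro on an aromatic carbon. Among the compounds with values here, no measured pair shows this change, so nothing in the data directly tells how it reads in this assay; the bromo simply takes the place of the chloro on the same aromatic carbon. The step of a 1.1-fold lower number from compound 1 to compound 4 (0.06 log units; within the scatter) is expected to be no larger than the scatter allows, in either direction. The estimate for compound 4 in this assay is 32000 nM, with a range from 13000 nM to 80000 nM.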

Compound 4, half-maximal inhibitory concentration: 31700 nM
Estimate against measurement, compound 4: 1.0-fold (0.00 log units) above, within the range that was stated.
By their numbers in this assay, from the lowest: compounds 4, 1, 2 and 3 (each within the scatter of the next, the first and the last beyond it).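

In this assay, bromo in place of chloro on this aromatic carbon gives a 1.2-fold lower number from compound 1 to compound 4 (0.06 log units; within the scatter), so 4-chlorophenyl and 4-bromophenyl cannot be told apart on the shared core. Within the data shown here, this is the first pair among the compounds that differs in one place, and it shows directly that at this position, para to a large group, the exchange of these two halogens leaves no reading that the assay can separate. Nothing measured here bears on why the two read alike.

The compounds shown leave open how this position reads with a group other than these two halogens, such as fluoro, an amine, a carboxylic acid or a longer chain. They also leave open whether the same exchange would read alike on the other aromatic ring of the core.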